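Chlorophenyl to chloropyridine on the amide carbonyl

The source may hold more compounds than are shown below. What is called first, only, known or untested is meant among the compounds shown, and "the series" means these compounds.

Compound 3 `O=C(Nc1ccc(Cl)c(-c2nnc3c(Cl)cccn23)c1)c1cccc(Cl)c1` gives 66100 nM in a functional assay on MDA-MB-231 cells (Homo sapiens) for antiproliferative activity, read by MTT assay, with stated times of 72 h and 4 h (a higher number here means a weaker inhibitor, a lower number a stronger inhibitor), the lowest of the two numbers recorded there. Compound 1 `O=C(Nc1ccc(Cl)c(-c2nnc3c(Cl)cccn23)c1)c1ccc(F)cc1Cl` gives 75000 nM in this assay, and the step of a 1.1-fold lower number from compound 1 to compound 3 (0.05 log units; within the scatter) stays within the scatter. Compound 2 `Cc1nc(C(=O)Nc2ccc(Cl)c(-c3nnc4c(Cl)cccn34)c2)cs1` reaches only a limit of this assay, > 100000 nM. The steps of an at least 1.3-fold higher number from compound 1 to compound 2 (0.12 log units; that floor lies within the scatter) and an at least 1.5-fold lower number from compound 2 to compound 3 (0.17 log units; that floor lies within the scatter) carry floors that also lie within the scatter. Compound 4 `O=C(Nc1ccc(Cl)c(-c2nnc3c(Cl)cccn23)c1)c1cccnc1Cl` differs from compound 3 by 2-chloropyridin-3-yl in place of 3-chlorophenyl on a carbonyl carbon. Among the compounds with values here, no measured step exchanges a ring carbon for a ring nitrogen, and every measured step sits within the scatter, so the change a 1.1-fold higher number from compound 3 to compound 4 (0.02 log units; within the scatter) is expected to stay within it as well. Compound 4 is therefore estimated at 70000 nM, in a range from 35000 nM to 140000 nM.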

Compound 4, half-maximal inhibitory concentration: 89700 nM
The estimate for compound 4 lay 1.3-fold (0.11 log units) below the measured number; measured number inside the range.
By their numbers in this assay, from the lowest: compounds 3, 1 and 4 (each within the scatter of the next). At a limit, above all of these: compound 2.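

With 2-chloropyridin-3-yl in place of 3-chlorophenyl on a carbonyl carbon, a ring nitrogen and a hydrogen-bond acceptor enter, yet the step stays within the scatter: it is a 1.4-fold higher number from compound 3 to compound 4 (0.13 log units; within the scatter). The same holds against the 2-chloro-4-fluorophenyl amide: a 1.2-fold higher number from compound 1 to compound 4 (0.08 log units; within the scatter). Compound 2 stands at a limit: the limit of > 100000 nM in this assay, at which 1 of the 4 values shown sits. That limit leaves only a floor for the remaining step, an at least 1.1-fold lower number from compound 2 to compound 4 (0.04 log units; that floor lies within the scatter).

The pair does not separate the ring nitrogen from the change between 3-chlorophenyl and 2-chloropyridin-3-yl in where the chlorine sits. On these data alone, whether an amine or a carboxylic acid on this carbonyl carbon would move the number beyond the scatter stays open.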